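The source may report more compounds than this note shows. Statements on the series, on what has been measured and on what is new or still open speak of the compounds shown alone.

In a functional assay on MDA-MB-231 cells (Homo sapiens) for antiproliferative activity, read by MTT assay, with a stated time of 72 h (on this read-out lower numbers stand for stronger inhibition and higher numbers for weaker inhibition), compound 1 (`COc1cc(/C=C/C(=O)/C=C(O)/C=C/c2ccc(OC(=O)C(C)(CO)CO)c(OC)c2)ccc1OC(=O)C(C)(CO)CO`) gives 2670 nM. Two relatives have been measured in the same test: compound 2 (`CCC(CO)(CO)C(=O)Oc1ccc(/C=C/C(=O)/C=C(O)/C=C/c2ccc(O)c(OC)c2)cc1OC`) gives 4660 nM and compound 3 (`COc1ccc(/C=C/C(=O)/C=C(O)/C=C/c2ccc(OC)c(OC(=O)C(C)(CO)CO)c2)cc1OC(=O)C(C)(CO)CO`) gives 4610 nM. Repeated measurements of this kind naturally scatter, and compound 1 lies within that scatter of both relatives, so these numbers do not set it apart from either one.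

The next compound, compound 4 (`COc1ccc(/C=C/C(O)=C/C(=O)/C=C/c2ccc(OC(=O)C(C)(CO)CO)c(OC)c2)cc1OC`), is reached from compound 1 by a single edit: methyl in place of (1,1-bis(hydroxymethyl)ethyl)carbonyl on an oxygen on an aromatic ring. The second such group of compound 1 remains, and the shared core is untouched.

Going by the values given here, no measured pair shows this edit on its own, so there is no direct precedent for its size. Among the compounds with values here, the only guide is how tightly the three structures cluster in this assay, with compound 1 at 2670 nM and compound 3 at 4610 nM. A small move toward a higher number is therefore expected, with nothing beyond the scatter. The estimated step is a 1.3-fold higher number from compound 1 to compound 4 (0.12 log units; within the scatter), which stays inside the usual scatter. For compound 4, the expected value is 3500 nM, within an estimated range of 1500 nM to 8000 nM.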

Compound 4, half-maximal inhibitory concentration: 2550 nM
For compound 4 the middle estimate is 1.4-fold (0.14 log units) above the measured one; the range from low to high includes it.
By their numbers in this assay, from the lowest: compounds 4, 1, 3 and 2 (each within the scatter of the next).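

In this assay, the first direct view of this edit gives a 1.0-fold lower number from compound 1 to compound 4 (0.02 log units; within the scatter), and that step lies within the usual scatter of repeated measurements. The change is not small in structural terms: the (1,1-bis(hydroxymethyl)ethyl)carbonyl that leaves has 8 heavy atoms, 2 hydrogen-bond donors and 3 hydrogen-bond acceptors, whereas the methyl that enters has 1 heavy atom and neither donors nor acceptors, yet this read-out does not separate compound 1 from compound 4. So, with the second such group in place, this oxygen on an aromatic ring can carry either group without a difference that this assay can resolve, although no measurement at hand says why.

The compounds shown leave open whether this tolerance extends to quite different groups on the same oxygen, such as a longer chain like butyl, a chain ending in an amine, or one ending in a carboxylic acid. They also leave open whether the same edit would give a similar result with the second (1,1-bis(hydroxymethyl)ethyl)carbonyl replaced by methyl as well.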